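The source may report more compounds than this note shows. Statements on the series, on what has been measured and on what is new or still open speak of the compounds shown alone.

Measured so far:
compound 1 `O=C1NC(=O)/C(=C/c2ccc(OCCSc3nnc(-c4ccccc4)[nH]3)cc2)S1` gives 26.4%
compound 2 `O=C1NC(=O)/C(=C/c2ccc(OCCSc3nnc(Cc4ccccc4)[nH]3)cc2)S1` gives 38.3%
compound 3 `O=C1NC(=O)/C(=C/c2ccc(OCCSc3nnc(-c4ccccc4)o3)cc2)S1` gives 24.1%

These three compounds were tested in a functional assay on the whole organism (strain Wistar) with Rattus norvegicus as the target, with a stated time of 15 days, at a dose of 30 mg/kg by the oral route; on this read-out higher numbers stand for a stronger effect at the one dose given and lower numbers for a weaker effect. Compound 1 and compound 2 share one core and differ by a single change, (benzyl in place of phenyl on an aromatic carbon), which made a number 11.9 percentage points higher from compound 1 to compound 2 (beyond the scatter). Compound 3 carries a different core; how that core differs from the core of compound 1 is not broken down here, and the two values of compound 1 and compound 3 lie within the scatter of each other.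

Compound 4 `O=C1NC(=O)/C(=C/c2ccc(OCCSc3nnc(Cc4ccccc4)o3)cc2)S1` is not yet measured. It is made from compound 3 by the same kind of change, (benzyl in place of phenyl on an aromatic carbon). The surroundings are not identical: in compound 1 the group sits between two ring nitrogen atoms of a ring with 3 nitrogen, whereas in compound 3 it sits next to the ring nitrogen and next to the ring oxygen of a ring with 2 nitrogen and 1 oxygen.

On the strength of the step seen as a number 11.9 percentage points higher from compound 1 to compound 2 (beyond the scatter), the step from compound 3 to compound 4 is expected to be about a number 10.9 percentage points higher from compound 3 to compound 4 (beyond the scatter) in this assay. Compound 4 is therefore estimated at 35%, with a range from 22% to 48%.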

Compound 4, a percentage reported as activity, at one dose (the size of the read-out at that dose, not a potency): 28%
The estimate for compound 4 lay 7 percentage points above the measured number; measured number inside the range.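

In this assay, benzyl in place of phenyl on an aromatic carbon gave a number 3.9 percentage points higher from compound 3 to compound 4 (within the scatter), so on this core the change cannot be told apart from repeat measurement. Set beside the earlier step on the other core, the new step does not differ from it by more than the scatter allows: the same change on two cores in this assay, a number 11.9 percentage points higher (beyond the scatter) from compound 1 to compound 2 and a number 3.9 percentage points higher (within the scatter) from compound 3 to compound 4, 8 percentage points apart, within the scatter of two such steps. For the compounds shown here, this fits a change that carries over from one core to the other, but it does not establish that, as there are only two steps, both at a single dose and one of them within the scatter, and they show neither that the step is the same on both cores nor that it differs.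

The compounds shown leave open whether a longer chain such as phenethyl, or an amine or a carboxylic acid in place of benzyl, would behave alike on both cores. They also leave open whether the step between phenyl and benzyl would look the same at another dose.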